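A few compounds are considered here, and "the series" means these few. Any claim that something is new, unique, unknown or untested is made for them only; others in the source may bear on it.

Measured so far:

Compound 1, `CC(=O)c1cccc(NC(=O)N[C@@H](C)c2ccccc2)c1`; in an ADME assay on the whole organism with Oryza sativa as the target, tested at 0.1 uM (on this read-out lower numbers stand for a stronger effect and higher numbers for a weaker effect at the one concentration tested), compound 1 gives 96%.
Compound 2, `CC(=O)c1ccc(NC(=O)N[C@H](C)c2ccccc2)cc1`; in this assay compound 2 gives 96%.
Compound 3, `C[C@H](NC(=O)Nc1cccc(F)c1)c1ccccc1`; in this assay compound 3 gives 97%.

Compound 1 and compound 2 share the same atoms joined differently; the difference between the two cores is not broken down here. Their values in this assay sit level at the digits read, and the gap from compound 2 to compound 3 is within the scatter, so no order among the three can be read from these numbers.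

One structural change is seen twice in the series. From compound 1 to compound 3 it is fluoro in place of acetyl on an aromatic carbon and gives a number 1 percentage points higher from compound 1 to compound 3 (within the scatter). Compound 4, `C[C@@H](NC(=O)Nc1ccc(F)cc1)c1ccccc1`, is not yet measured; it stands to compound 2 as fluoro in place of acetyl on an aromatic carbon, the same kind of change, the place differing only in that the group sits para to a large group rather than meta to a large group.

Because the measured instance gave a number 1 percentage points higher from compound 1 to compound 3 (within the scatter), the step expected from compound 2 to compound 4 in this assay is a number 1 percentage points higher from compound 2 to compound 4 (within the scatter). Compound 4 is therefore estimated at 97%, with an expected range from 90% to 100%.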

Compound 4, a percentage reported as activity, at one concentration (the size of the read-out at that concentration, not a potency): 98%
The estimate for compound 4 lay 1 percentage points below the measured number; the range from low to high includes it.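

In this assay, fluoro in place of acetyl on an aromatic carbon gives a number 2 percentage points higher from compound 2 to compound 4 (within the scatter), and this step agrees with the earlier one on the other core: the same change on two cores in this assay, a number 1 percentage points higher (within the scatter) from compound 1 to compound 3 and a number 2 percentage points higher (within the scatter) from compound 2 to compound 4, 1 percentage points apart, within the scatter of two such steps

The change therefore carries from the core of compound 1 to the core of compound 2 without a readable difference between the two steps. This agreement is only between two steps that each lie within the scatter, so it shows neither that the change has a real effect on the read-out nor how a larger effect would transfer, and it covers only these two cores at the one concentration tested.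

The compounds shown carry only acetyl or fluoro at the varied aromatic carbon, leaving open what an amine, a carboxylic acid or a nitrile would do there, and what a longer chain would do in place of the methyl. Also open, going by these compounds, is whether any such replacement gives a step beyond the scatter and, if so, whether that step holds on both cores.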